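Cyclopropane acid in place of gem-dimethyl acid

This account rests on a few compounds, and the source may have more. Where it says the series, first, only, none or still open, it means among the compounds named here.

Measured so far:
compound 1 `Cc1nn(-c2ccccn2)c2cc(-c3ccc(CC(C)(C)C(=O)O)cc3)ccc12` 18%
compound 2 `COc1cc(CCC(=O)O)ccc1-c1ccc2c(C)nn(-c3ccccn3)c2c1` 62%

In a functional assay on cells for agonist activity at Free fatty acid receptor 1 (Mus musculus), read by FLIPR and calcium flux, with a stated time of 5 min (a higher number here means a larger maximal response, a lower number a smaller maximal response), compound 1 gives 18%, the lower of the two numbers in hand. Among the measured compounds shown here, compound 2 sits well above it in this assay, by a margin beyond the scatter, but the two compounds differ in more than one place, so no single step is drawn between them; the pair only shows the span of responses the shared core can reach.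

Compound 3 `Cc1nn(-c2ccccn2)c2cc(-c3ccc([C@@H]4C[C@H]4C(=O)O)cc3)ccc12` keeps that core and alters the acid-bearing side chain: 2-carboxycyclopropyl in place of 2-carboxy-2-methylpropyl on an aromatic carbon. For the measured compounds named here, no measured pair isolates this kind of change, so the size of the step is open. A modest rise from the low position of compound 1 is expected, a number 12 percentage points higher from compound 1 to compound 3 (beyond the scatter), with the possibility that it stays within the scatter. Compound 3 is estimated at 30% in this assay, within 10% to 60%.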

Compound 3, largest response reached (reported as efficacy), in percent of the reference or control that the assay uses: 2%
Compound 3: the middle estimate sits 28 percentage points above what was measured; measured number outside the range, below it.
By their numbers in this assay, from the lowest: compound 3; then compound 1; then compound 2.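

At this position, on an aromatic carbon para to a large group, the maximal response is sensitive to the shape of the acid-bearing side chain: in this assay, 2-carboxycyclopropyl in place of 2-carboxy-2-methylpropyl gives a number 16 percentage points lower from compound 1 to compound 3 (beyond the scatter), and compound 3 keeps almost no response. On this core, then, the cyclopropane acid with its 2 defined stereocentres does not stand in for the gem-dimethyl acid, and even the low response of compound 1 is not retained. Nothing measured here accounts for the drop.

On these data alone, how the mirror-image form of 2-carboxycyclopropyl would respond at this position remains open, so the result cannot yet be assigned to the three-membered ring or to this stereochemistry. Also open, as far as these compounds go, is the response of a carboxymethyl group here, or of a tetrazole in place of the carboxylic acid.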